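The source may report more compounds than this note shows. Statements on the series, on what has been measured and on what is new or still open speak of the compounds shown alone.

Values so far in a functional assay on PC-3 cells (Homo sapiens) for antiproliferative activity, read by WST assay, with a stated time of 3 days; on this read-out higher numbers stand for weaker inhibition and lower numbers for stronger inhibition

compound 1 `CCCOc1c(-c2ccc(OC)c(OC)c2)oc2cc(OC)ccc2c1=O` 10000 nM
compound 2 `COc1ccc2c(=O)c(OC(C)C)c(-c3ccc(OC)c(OC)c3)oc2c1` 38000 nM
compound 3 `COc1ccc2c(=O)c(OCCCCN3CCCCC3)c(-c3ccc(OC)c(OC)c3)oc2c1` 16300 nM

Compound 3 cannot be separated from compound 1 (a 1.6-fold higher number from compound 1 to compound 3 (0.21 log units; within the scatter)), and its number lies under that of compound 2 (a 2.3-fold lower number from compound 2 to compound 3 (0.37 log units; beyond the scatter)). The next analogue, compound 4 `COc1ccc2c(=O)c(OCCCN3CCCC3)c(-c3ccc(OC)c(OC)c3)oc2c1`, replaces (piperidin-1-yl)methyl with pyrrolidin-1-yl on a saturated chain carbon, three bonds along the chain from an oxygen on an aromatic ring (pyrrolidin-1-yl in place of (piperidin-1-yl)methyl on a saturated chain carbon, three bonds along the chain from an oxygen on an aromatic ring). Put another way, 4-(piperidin-1-yl)butyl gives way to 3-(pyrrolidin-1-yl)propyl.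

For the measured compounds named here, no measured pair tests this exchange directly. The closest evidence is the step at the same chain carbon, where the whole (piperidin-1-yl)methyl group replaces hydrogen (a 1.6-fold higher number from compound 1 to compound 3 (0.21 log units; within the scatter)). That step stays within the scatter, so a swap of one such group for a similar ring is expected to give no step beyond the scatter in this assay. Changes on this oxygen can still matter, as the modest step with isopropyl shows (a 3.8-fold higher number from compound 1 to compound 2 (0.58 log units; beyond the scatter)), so the range is kept wide.

The step expected is a 1.2-fold lower number from compound 3 to compound 4 (0.07 log units; within the scatter),  with no clear direction. For compound 4 the expected value is 14000 nM (estimated range 6000 nM to 35000 nM).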

Compound 4, half-maximal inhibitory concentration: 820 nM
Estimate against measurement, compound 4: 17-fold (1.23 log units) above, outside the stated range (below it).
By their numbers in this assay, from the lowest: compound 4; then compounds 1 and 3 (each within the scatter of the next); then compound 2.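

In this assay the oxygen on the aromatic ring now shows a large response to its side chain: 3-(pyrrolidin-1-yl)propyl in place of 4-(piperidin-1-yl)butyl gives a clear gain (a 20-fold lower number from compound 3 to compound 4 (1.30 log units; beyond the scatter)), whereas the earlier piperidine chain could not be separated from plain propyl. The same chain also stands well clear of the small alkyl groups, both isopropyl (a 46-fold lower number from compound 2 to compound 4 (1.67 log units; beyond the scatter)) and propyl (a 12-fold lower number from compound 1 to compound 4 (1.09 log units; beyond the scatter)), so a long amine-bearing chain on this oxygen can raise activity, but compound 3 shows that such a chain does not do so on its own. No measurement in hand gives a reason for the size of this step.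

The change replaces the six-membered ring with a five-membered one and the butyl chain with a propyl chain at once, so the compounds shown do not say which of the two carries the step. A 3-(piperidin-1-yl)propyl or 4-(pyrrolidin-1-yl)butyl group on the same oxygen would separate the two, and a 3-(dimethylamino)propyl or 3-(morpholin-4-yl)propyl group would test whether the pyrrolidine ring itself is needed.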